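The source may report more compounds than this note shows. Statements on the series, on what has been measured and on what is new or still open speak of the compounds shown alone.

Measured compounds:
Compound 1, `CC(C)(C)c1ccc(C(=O)N2CCC3(CC2)C(=O)N(CC(=O)NCN)CN3c2ccccc2)cc1`, gives 26500 nM in an assay on HEK293 cells for displacement of a labelled ligand from NPC1-like intracellular cholesterol transporter 1 (Homo sapiens); on this read-out lower numbers stand for stronger inhibition and higher numbers for weaker inhibition.
Compound 2, `CC(C)(C)c1ccc(C(=O)N2CCC3(CC2)C(=O)N(CC(=O)N2CCC(O)CC2)CN3c2ccccc2)cc1`, gives 4700 nM in this assay.
Compound 3, `COC(=O)CCCNC(=O)CN1CN(c2ccccc2)C2(CCN(C(=O)c3ccc(C(C)(C)C)cc3)CC2)C1=O`, has "not determined" (no result reported) in this assay.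

Compound 3 therefore stands nowhere on the numbers shown: it was made, but no number for it in this assay is known. Compound 4, `CCC1CCCN(C(=O)CN2CN(c3ccccc3)C3(CCN(C(=O)c4ccc(C(C)(C)C)cc4)CC3)C2=O)C1`, differs from it in one place: 3-ethylpiperidin-1-yl in place of (3-(methoxycarbonyl)propyl)amino on a carbonyl carbon. Within the data shown here, only one measured step bears on this kind of change, and only loosely: a 5.6-fold lower number from compound 1 to compound 2 (0.75 log units; beyond the scatter), where an open-chain amino group on the same carbonyl carbon was likewise exchanged for a piperidine ring. That step gave a modestly lower number, beyond the scatter. Since compound 3 has no number, the estimate for compound 4 can only be anchored on compound 2, the measured piperidine amide of the shared core, and on the direction of that one step. On this basis compound 4 is expected to land near compound 2 in this assay, with a wide margin in both directions; the estimated value for compound 4 is 3000 nM, in a range from 700 nM to 13000 nM.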

Compound 4, half-maximal inhibitory concentration: 3900 nM
For compound 4 the middle estimate is 1.3-fold (0.11 log units) below the measured one, within the range that was stated.
By their numbers in this assay, from the lowest: compounds 4 and 2 (each within the scatter of the next); then compound 1.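

In this assay, the exchange of one substituted piperidine for another leaves the number in place, a 1.2-fold lower number from compound 2 to compound 4 (0.08 log units; within the scatter), so on this carbonyl carbon a 3-ethylpiperidin-1-yl group reads the same as a 4-hydroxypiperidin-1-yl group. The lower number relative to the open-chain group of compound 1 now holds for a second piperidine amide, a 6.8-fold lower number from compound 1 to compound 4 (0.83 log units; beyond the scatter), where earlier it rested on a single step. The exchange from compound 3 cannot be read, that compound having no number, and no supporting data bear on why these two rings read alike.

The compounds shown leave open how an unsubstituted piperidin-1-yl group, a morpholine ring or a piperidine carrying a carboxylic acid would compare with compound 2 and compound 4. They also leave open whether a simple open-chain alkylamine amide, without the terminal amine of compound 1, would read like these rings.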